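From 2,4-difluorophenyl to pyridin-3-yl on the shared core

A few compounds are considered here, and "the series" means these few. Any claim that something is new, unique, unknown or untested is made for them only; others in the source may bear on it.

Among the measured compounds shown here, in a functional assay on MIA PaCa-2 cells (Homo sapiens) for cytotoxicity, read by MTT assay, with a stated time of 4 h (a higher number here means a weaker inhibitor, a lower number a stronger inhibitor), compound 1 `COC1=CC(=O)c2c(COc3ccccc3)c(C)n(C)c2C1=O` gives 4560 nM and compound 2 `COC1=CC(=O)c2c(COc3ccc(F)cc3F)c(C)n(C)c2C1=O` gives 255 nM as the lowest of the two numbers so far. Compound 2 is thus the stronger inhibitor of the pair. The next structure is compound 3 `COC1=CC(=O)c2c(COc3cccnc3)c(C)n(C)c2C1=O` with the shared core unchanged. The difference is pyridin-3-yl in place of 2,4-difluorophenyl on an oxygen on a saturated carbon and it puts pyridin-3-yl in place of 2,4-difluorophenyl on an oxygen on a saturated carbon. For the measured compounds named here, the one measured step that bears on this is an 18-fold lower number from compound 1 to compound 2 (1.25 log units; beyond the scatter) and that large step, well beyond the scatter, came with 2,4-difluorophenyl in place of phenyl. Compound 3 gives up the 2,4-difluorophenyl again, so much of that gain is expected to be lost. Going by the values given here, no measured compound carries a ring with a hetero atom, so how pyridin-3-yl compares with phenyl remains open. A clear move to a higher number is therefore expected in this assay with a 5.9-fold higher number from compound 2 to compound 3 (0.77 log units; beyond the scatter) as the estimated step. For compound 3 the expected value is 1500 nM with an estimated range from 350 nM to 6000 nM as a deliberately wide window.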

Compound 3, half-maximal inhibitory concentration: 2480 nM
Estimate against measurement, compound 3: 1.7-fold (0.22 log units) below, and the stated range covers the measured number.
By their numbers in this assay, from the lowest: compound 2; then compounds 3 and 1 (each within the scatter of the next).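

In this assay the pyridin-3-yl group on this oxygen brings a 9.7-fold higher number from compound 2 to compound 3 (0.99 log units; beyond the scatter) and so does not keep the low number seen with 2,4-difluorophenyl, which shows that this place tolerates some ring swaps far less well than the first step alone could reveal. Set against the plain ring, pyridin-3-yl in place of phenyl gives a 1.8-fold lower number from compound 1 to compound 3 (0.26 log units; within the scatter) and, lying within the usual scatter, shows no real difference between these two rings in this assay, so among the three groups only 2,4-difluorophenyl stands apart. Nothing measured here explains why these numbers fall as they do.

The compounds shown leave open whether a phenyl ring carrying a single fluorine, or instead chlorine or a methoxy group, would reach the low number of compound 2 or stay with compounds 1 and 3. They also leave open whether adding fluorine to the pyridin-3-yl ring would bring a similar drop in the number, or whether that drop belongs to the carbon-only ring.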